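Acyl variation on the dodecylamide threonine series

This account rests on a few compounds, and the source may have more. Where it says the series, first, only, none or still open, it means among the compounds named here.

Measured compounds:
compound 1 `CCCCCCCCCCCCNC(=O)[C@@H](NC(=O)c1nccc2ccccc12)[C@@H](C)O` — 56600 nM
compound 2 `CCCCCCCCCCCCNC(=O)[C@@H](NC(=O)c1cc2ccccc2[nH]1)[C@@H](C)O` — 21300 nM
compound 3 `CCCCCCCCCCCCNC(=O)[C@@H](NC(=O)/C=C/c1ccccc1)[C@@H](C)O` — > 200000 nM

In a functional assay on SiHa cells (Homo sapiens) for cytotoxicity, read by MTT assay, with a stated time of 48 h (on this read-out lower numbers stand for stronger inhibition and higher numbers for weaker inhibition), compound 1 gives 56600 nM and compound 2 gives 21300 nM, with a 2.7-fold lower number from compound 1 to compound 2 (0.42 log units; beyond the scatter). For compound 3 the read-out is a limit, not a number: > 200000 nM (the limit of > 200000 nM in this assay, at which 1 of the 3 values shown sits). Compound 3 therefore stands at the weak end of the series, since an at least 3.5-fold higher number from compound 1 to compound 3 (0.54 log units; beyond the scatter) and an at least 9.3-fold higher number from compound 2 to compound 3 (0.97 log units; beyond the scatter) both go beyond the scatter.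

Compound 4 `C/C=C/C=C/C(=O)N[C@H](C(=O)NCCCCCCCCCCCC)[C@@H](C)O` keeps the core of compound 3 and changes only the far end of the acyl group: prop-1-en-1-yl in place of phenyl on a double-bonded chain carbon bound to a double-bonded chain carbon. Going by the values given here, no measured step covers this change. The three measured steps all swap the whole group on the carbonyl carbon, and the two that lead to compound 3 exchange a group carrying a fused aromatic ring for 2-phenylethenyl and land at the limit. Compound 4 removes the last aromatic ring from that position. In this assay compound 4 is expected to remain at or beyond the limit, with a step that the limit leaves unreadable from compound 3 to compound 4 as the expected step. The estimate for compound 4 is 250000 nM, between 100000 nM and 700000 nM.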

Compound 4, half-maximal inhibitory concentration: > 200000 nM
Compound 4 was reported as a limit; the forecaster's own chance of this, stated with the estimate: 80%; the middle value lies beyond the limit too.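

Compound 4 shows that an acyl group with no ring at all, penta-1,3-dien-1-yl on the carbonyl carbon, also stands at the weak end in this assay: an at least 9.3-fold higher number from compound 2 to compound 4 (0.97 log units; beyond the scatter) and an at least 3.5-fold higher number from compound 1 to compound 4 (0.54 log units; beyond the scatter). Replacing phenyl with prop-1-en-1-yl gives no readable step, as compound 3 and compound 4 are both reported as limits, not numbers. Among the compounds shown, readable values therefore remain confined to the isoquinolin-1-yl and 1H-indol-2-yl groups, while compound 3, with its phenyl ring, and compound 4, without a ring, both stand at the limit: the limit of > 200000 nM in this assay, at which 2 of the 4 values shown sit.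

As far as these compounds go, it remains open whether the phenyl and prop-1-en-1-yl ends differ at all beyond this limit. From the compounds shown here alone, it is also open whether a saturated pentyl group on the carbonyl carbon, or an amine or a carboxylic acid at the far end of the acyl chain, would give a readable value.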